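The source may hold more compounds than are shown below. What is called first, only, known or untested is meant among the compounds shown, and "the series" means these compounds.

Measured so far in a functional assay on MGC-803 cells (Homo sapiens) for cytotoxicity, read by MTT assay, with a stated time of 72 h; a lower number here means a stronger inhibitor, a higher number a weaker inhibitor:

Compound 1, `FC(F)(F)c1ccc(CSc2nc(Nc3ccc(C(F)(F)F)cc3)c3ccccc3n2)cc1`, gives 6170 nM.
Compound 2, `COc1ccc(Nc2nc(SCc3ccc(C(F)(F)F)cc3)nc3ccccc23)cc1`, gives 13800 nM.
Compound 3, `COc1cc(Nc2nc(SCc3ccc(C(F)(F)F)cc3)nc3ccccc23)cc(OC)c1`, gives 8580 nM.

Compound 3 sits second highest of the three numbers in this assay; its nearest neighbour is compound 1 and its furthest is compound 2, and both gaps lie within the scatter: a 1.4-fold higher number from compound 1 to compound 3 (0.14 log units; within the scatter) and a 1.6-fold lower number from compound 2 to compound 3 (0.21 log units; within the scatter). Within the data shown here, the only step beyond the scatter is a 2.2-fold higher number from compound 1 to compound 2 (0.35 log units; beyond the scatter), a modest one.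

Compound 4, `COc1ccc(Nc2nc(SCc3ccc(C(F)(F)F)cc3)nc3ccccc23)cc1OC`, differs from compound 3 in one place: 3,4-dimethoxyphenyl in place of 3,5-dimethoxyphenyl on a nitrogen on an aromatic ring. The two steps that bear on it, the aryl swaps that gave compound 3, both stayed within the scatter, so no step beyond the scatter is expected in this assay from compound 3 to compound 4; if anything a slightly higher number, in line with the direction of compound 2 in a 2.2-fold higher number from compound 1 to compound 2 (0.35 log units; beyond the scatter), is expected. Compound 4 is estimated at 9500 nM, with a range of 4500 nM to 20000 nM. The step this estimate implies is expected to be a 1.1-fold higher number from compound 3 to compound 4 (0.04 log units; within the scatter).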

Compound 4, half-maximal inhibitory concentration: 16300 nM
For compound 4 the middle estimate is 1.7-fold (0.23 log units) below the measured one; the range from low to high includes it.
By their numbers in this assay, from the lowest: compounds 1, 3, 2 and 4 (each within the scatter of the next, the first and the last beyond it).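

In this assay, the swap of 3,5-dimethoxyphenyl for 3,4-dimethoxyphenyl on the nitrogen gives a 1.9-fold higher number from compound 3 to compound 4 (0.28 log units; within the scatter), so these two dimethoxy arrangements are not resolved from each other. Methoxy in place of hydrogen on an aromatic carbon gives a 1.2-fold higher number from compound 2 to compound 4 (0.07 log units; within the scatter), so the added methoxy on the 4-methoxyphenyl group is not resolved either. The 4-(trifluoromethyl)phenyl group of compound 1 now stands apart from two methoxy-bearing aryl groups, with a 2.6-fold higher number from compound 1 to compound 4 (0.42 log units; beyond the scatter) alongside a 2.2-fold higher number from compound 1 to compound 2 (0.35 log units; beyond the scatter), while compound 3 goes against this pattern with a 1.4-fold higher number from compound 1 to compound 3 (0.14 log units; within the scatter).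

Nothing available bears on the cause of these steps. On these data alone, it remains open whether an amine or a carboxylic acid on this aryl ring, in place of methoxy, would give a step beyond the scatter from compound 1.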